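From a Pentyl Chain to a Single Fluorine

A few compounds are considered here, and "the series" means these few. Any claim that something is new, unique, unknown or untested is made for them only; others in the source may bear on it.

Two ureas built on a shared core have been examined in an ADME assay on the whole organism with Oryza sativa as the target, tested at 0.1 uM; on this read-out higher numbers stand for a weaker effect at the one concentration tested and lower numbers for a stronger effect. Compound 1 `CCCc1ccc(NC(=O)N[C@H](C)c2ccccc2)cc1` carries a propyl group on an aromatic carbon and gives 33% in this assay. Compound 2 `CCCCCc1ccc(NC(=O)N[C@H](C)c2ccccc2)cc1` carries a pentyl group on an aromatic carbon and gives 100%. Going by the values given here, of the two numbers, compound 2 stands highest, and the only measured step is a number 67 percentage points higher from compound 1 to compound 2 (beyond the scatter), arising from ethyl in place of hydrogen on a saturated chain carbon, three bonds along the chain from an aromatic carbon.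

Compound 3 `C[C@@H](NC(=O)Nc1ccc(F)cc1)c1ccccc1` has not yet been measured in this assay. It differs from compound 2 by fluoro in place of pentyl on an aromatic carbon. Among the compounds with values here, the single step that bears on this change is a number 67 percentage points higher from compound 1 to compound 2 (beyond the scatter), and it was large; there the chain grew longer, whereas here the pentyl group is removed altogether and fluoro takes its place on the aromatic carbon. A large step in the opposite direction is therefore expected for compound 3, namely a number 80 percentage points lower from compound 2 to compound 3 (beyond the scatter). Compound 3 is estimated to give 20%, with a range from 0% to 60%.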

Compound 3, a percentage reported as activity, at one concentration (the size of the read-out at that concentration, not a potency): 98%
For compound 3 the middle estimate is 78 percentage points below the measured one, outside the stated range (above it).
By their numbers in this assay, from the lowest: compound 1; then compounds 3 and 2 (each within the scatter of the next).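

In this assay, fluoro in place of pentyl on this aromatic carbon, para to a large group, gives a number 2 percentage points lower from compound 2 to compound 3 (within the scatter), so a single fluorine in place of a chain of five carbons leaves the read-out where it was and does not bring it back towards that of compound 1. Fluoro in place of propyl at the same carbon gives a number 65 percentage points higher from compound 1 to compound 3 (beyond the scatter), which leaves compound 1 apart from the other two and shows that the earlier step cannot be read as a simple rise with the size of the group here, since compound 3, with the smallest group of the three, goes against such a reading. Nothing at hand accounts for the separate standing of the propyl compound.

Going by these compounds, it remains open whether the stronger effect belongs to propyl alone or to a wider span of chain lengths, a question that an ethyl or a butyl group on the same aromatic carbon would address. On these data alone, it is also open whether the result for fluoro extends to other single atoms or small groups at this place, such as chloro or methoxy.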